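Carbamoyl to carboxy on compound 1

The source may hold more compounds than are shown below. What is called first, only, known or untested is meant among the compounds shown, and "the series" means these compounds.

In a physicochemical assay for lipophilicity, using the shake flask method (on this read-out lower numbers stand for lower lipophilicity and higher numbers for higher lipophilicity), compound 1 `C[C@H](Oc1ccc(NC(=O)CC(N)=O)c(C2CC2)n1)c1c(Cl)ccc(F)c1Cl` gives 3.7. Compound 2 `C[C@H](Oc1ccc(/C=C/C(=O)O)c(C2CC2)c1)c1c(Cl)ccc(F)c1Cl` gives 3.6, within the usual scatter of compound 1, while compound 3 `Cc1cnn(C)c1[C@H](C)Oc1ccc2ncc(/C=C/C(=O)O)c(C3CC3)c2c1` gives 0.9, far lower than compound 1.

Compound 4 `C[C@H](Oc1ccc(NC(=O)CC(=O)O)c(C2CC2)n1)c1c(Cl)ccc(F)c1Cl` differs from compound 1 in one place: hydroxy in place of amino on a carbonyl carbon. This puts hydroxy in place of amino on a carbonyl carbon, so carbamoylmethyl becomes carboxymethyl.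

Among the compounds with values here, no measured pair shows this swap on its own, so any forecast is loose. Two measured compounds do carry a carboxy group, though they differ from compound 1 in other ways too. In compound 2 that group comes with 3.6, and in compound 3 with 0.9, so it fixes no single level. Inside that wide span, a position well under compound 1 seems the likeliest outcome. The expected change is a fall beyond the scatter, estimated as a number 1.70 log units lower from compound 1 to compound 4 (beyond the scatter). For compound 4 the estimated value is 2, with an expected range of 1 to 3.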

Compound 4, distribution coefficient: 1.4
For compound 4 the middle estimate is 0.60 log units above the measured one; measured number inside the range.
By their numbers in this assay, from the lowest: compound 3; then compound 4; then compounds 2 and 1 (each within the scatter of the next).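

With hydroxy in place of amino on a carbonyl carbon as the only difference, the change brings a number 2.30 log units lower from compound 1 to compound 4 (beyond the scatter) in this assay, a large step. Compound 2 and compound 3 also carry a carboxy group but differ from compound 1 in other places, so they could not give the size of this swap alone, whereas this pair isolates it: exchanging one heavy atom, with the counted hydrogen-bond donors and acceptors the same on both sides, is enough to move the number this far. Nothing measured here explains why the number moves so far.

Going by these compounds, it remains open how the number would respond to a methyl ester, an amine or a longer chain ending in carboxy in place of carboxymethyl. Within the data shown here, whether the same swap gives a similar step on another core also remains open, as only this one pair carries it.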